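Amide Replacement in a Dimethoxy Tetralin Series

A few compounds are considered here, and "the series" means these few. Any claim that something is new, unique, unknown or untested is made for them only; others in the source may bear on it.

Measured compounds:
compound 1 `CCCNC(=O)CC1CCc2cc(OC)c(OC)cc21` gives 18.8%
compound 2 `COc1cc2c(cc1OC)C(CC(=O)NC(C)C)CC2` gives 31.3%
compound 3 `COc1cc2c(cc1OC)C(CC(=O)N1CCNCC1)CC2` gives 62.5%

In a functional assay on the whole organism (strain Wistar) for inhibition, with Rattus norvegicus as the target, read by paw edema, with stated times of 60 min and 1 h, at a dose of 100 mg/kg by the oral route (a higher number here means more inhibition at the dose given (going by the name of the read-out), a lower number less inhibition), compound 1 stands lowest of the three numbers. The nearest is compound 2, reached by a number 12.5 percentage points higher from compound 1 to compound 2 (beyond the scatter); the furthest is compound 3, reached by a number 43.7 percentage points higher from compound 1 to compound 3 (beyond the scatter). Compound 4 `COc1cc2c(cc1OC)C(CC(=O)N1CCOCC1)CC2` has not yet been measured. It differs from compound 1 by morpholin-4-yl in place of propylamino on a carbonyl carbon, the new group being one six-membered non-aromatic ring with two hetero atoms. The relevant comparisons are the two ring-bearing steps: compound 3 gained largely over compound 1, and also over compound 2 by a number 31.2 percentage points higher from compound 2 to compound 3 (beyond the scatter). Compound 4 is therefore expected to show a rise beyond the scatter, estimated as a number 26.2 percentage points higher from compound 1 to compound 4 (beyond the scatter). For compound 4 the estimate is 45%, ranging from 25% to 65%.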

Compound 4, a percentage reported as inhibition, in the whole organism at one dose (the size of the read-out at that dose, not a potency): 15.6%
Estimate against measurement, compound 4: 29.4 percentage points above, outside the stated range (below it).
By their numbers in this assay, from the lowest: compounds 4 and 1 (each within the scatter of the next); then compound 2; then compound 3.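

In this assay, a six-membered non-aromatic ring on the carbonyl carbon does not by itself bring the gain seen with piperazin-1-yl, as morpholin-4-yl gives a number 46.9 percentage points lower from compound 3 to compound 4 (beyond the scatter) and then a number 15.7 percentage points lower from compound 2 to compound 4 (beyond the scatter) against isopropylamino. Against propylamino it gives a number 3.2 percentage points lower from compound 1 to compound 4 (within the scatter) and so brings no gain over that open chain. At this position, then, the two rings part widely, with oxygen in morpholin-4-yl where piperazin-1-yl carries a second nitrogen.

On these data alone, whether 4-methylpiperazin-1-yl or piperidin-1-yl would stand nearer compound 3 or compound 4 stays open. Nothing measured here accounts for the gap between the two rings.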